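The source may hold more compounds than are shown below. What is called first, only, known or untested is meant among the compounds shown, and "the series" means these compounds.

Compound 1 `Cc1cc(C)cc(S(=O)(=O)c2cnc3ccc(C)cc3c2N2CCC(C)CC2)c1`, compound 2 `Cc1ccc2ncc(S(=O)(=O)c3ccc(Cl)cc3)c(N3CCC(C)CC3)c2c1` and compound 3 `Cc1cc(C)cc(S(=O)(=O)c2cnc3ccc(Cl)cc3c2N2CCC(C)CC2)c1` share one core, and compound 4 `CC1CCN(c2c(S(=O)(=O)c3ccc(Cl)cc3)cnc3ccc(Cl)cc23)CC1` joins them. In an assay on isolated protein for displacement of a labelled ligand from metabotropic glutamate receptor 5 (Homo sapiens), with a stated time of 60 min, tested at 1 uM (on this read-out lower numbers stand for less inhibition and higher numbers for more inhibition at the one concentration tested (going by the name of the read-out)), compound 1 gives 80%, compound 2 gives 79% and compound 3 gives 49%. The change 4-chlorophenyl in place of 3,5-dimethylphenyl on a sulfonyl sulfur brought a number 1 percentage points lower from compound 1 to compound 2 (within the scatter). The cores of compound 1 and compound 3 differ by chloro in place of methyl on an aromatic carbon, a change that brought a number 31 percentage points lower from compound 1 to compound 3 (beyond the scatter). Within the data shown here, the change 4-chlorophenyl in place of 3,5-dimethylphenyl on a sulfonyl sulfur is the same as the one from compound 1 to compound 2, at a place described in the same words. Compound 4 is therefore expected to sit close to compound 3, with an estimated step of a number 1 percentage points lower from compound 3 to compound 4 (within the scatter), resting on the small step seen from compound 1 to compound 2. For compound 4 the expected value in this assay is 48%, estimated between 32% and 64%.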

Compound 4, a percentage reported as inhibition, at one concentration (the size of the read-out at that concentration, not a potency): 92%
Beside the measured number, compound 4's estimate is 44 percentage points below it, and the stated range ends below it.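

In this assay, 4-chlorophenyl in place of 3,5-dimethylphenyl on the sulfonyl sulfur brought a number 43 percentage points higher from compound 3 to compound 4 (beyond the scatter), so this change did not carry over from one core to the other: the same change on two cores in this assay, a number 1 percentage points lower (within the scatter) from compound 1 to compound 2 and a number 43 percentage points higher (beyond the scatter) from compound 3 to compound 4, 44 percentage points apart, beyond the scatter of two such steps. Chloro in place of methyl on an aromatic carbon brought a number 13 percentage points higher from compound 2 to compound 4 (beyond the scatter), the opposite direction to its earlier step: the same change on two cores in this assay, a number 31 percentage points lower (beyond the scatter) from compound 1 to compound 3 and a number 13 percentage points higher (beyond the scatter) from compound 2 to compound 4, 44 percentage points apart, beyond the scatter of two such steps. Each change therefore depends on the group present at the other place in these four compounds, but this does not show why, or whether the same holds on any other core.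

On these data alone, it remains open how a methoxy group or a nitrile at that aromatic carbon would behave. With only one concentration tested, the potency of these compounds also remains open.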